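The source may report more compounds than this note shows. Statements on the series, on what has been measured and on what is new or still open speak of the compounds shown alone.

Working notes on the series, all read in a functional assay on MCF7 cells (Homo sapiens) for cytotoxicity, read by sulforhodamine B assay; on this read-out higher numbers stand for weaker inhibition and lower numbers for stronger inhibition. Compound 1 (`C=C1[C@@H](OC(C)=O)C[C@@H]2[C@](C)(CO[Si](C)(C)C(C)(C)C)[C@H](OC(C)=O)CC[C@@]2(C)[C@@H]1C[C@@H](Nc1ccc(OC)c(OC)c1)C1=CCOC1=O`) gives 4310 nM, and compound 2 (`C=C1[C@@H](OC(C)=O)C[C@@H]2[C@](C)(COC=O)[C@H](OC(C)=O)CC[C@@]2(C)[C@@H]1C[C@@H](Nc1ccccc1F)C1=CCOC1=O`) gives 16400 nM. Compound 3 (`C=C1[C@@H](OC(C)=O)C[C@@H]2[C@](C)(COC=O)[C@H](OC(C)=O)CC[C@@]2(C)[C@@H]1C[C@@H](Nc1ccc(OC)c(OC)c1)C1=CCOC1=O`) stands at > 50000 nM, which is a limit of the assay and not a number. Its steps from both other compounds are beyond the scatter, which places compound 3 at the weak end of the three.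

The next change gives compound 4 (`C=C1[C@@H](OC(C)=O)C[C@@H]2[C@](C)(COC=O)[C@H](OC(C)=O)CC[C@@]2(C)[C@@H]1C[C@@H](Nc1ccc(C(=O)O)cc1)C1=CCOC1=O`), with 4-carboxyphenyl in place of 3,4-dimethoxyphenyl on an amine nitrogen.

Among the measured compounds shown here, two measured steps bear on this. The closer one is an at least 3.0-fold higher number from compound 2 to compound 3 (0.48 log units; beyond the scatter), an exchange of aryl groups on the same amine nitrogen, and it is at least modest. The other, an at least 11-fold higher number from compound 1 to compound 3 (1.06 log units; beyond the scatter), is large but lies at a different place, on an oxygen on a saturated carbon, and compound 4 keeps the group found there in compound 3. For the measured compounds named here, no measured compound carries 4-carboxyphenyl, so the direction rests on little. Going by the values given here, compound 2 at 16400 nM is the only number measured with that group kept, so only a modest move towards a lower number is expected. The reading may also stay at the limit of the assay. The expected step is an at least 1.4-fold lower number from compound 3 to compound 4 (0.15 log units; that floor lies within the scatter). Compound 4 is estimated at 35000 nM, with an expected range of 12000 nM to 80000 nM.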

Compound 4, half-maximal inhibitory concentration: 41700 nM
Compound 4: middle estimate off by 1.2-fold (0.08 log units), on the low side, and the stated range covers the measured number.
By their numbers in this assay, from the lowest: compound 1; then compound 2; then compound 4. At a limit, above all of these: compound 3.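

Among the aryl groups on this amine nitrogen, this assay now gives a 2.5-fold higher number from compound 2 to compound 4 (0.41 log units; beyond the scatter), which places 4-carboxyphenyl on the weak side of 2-fluorophenyl with the rest of the molecule unchanged. The exchange of 3,4-dimethoxyphenyl for 4-carboxyphenyl reads only as an at least 1.1-fold lower number from compound 3 to compound 4 (0.07 log units; that floor lies within the scatter), and since that floor lies within the scatter, the true size of this step and whether the two groups differ at all remain unresolved. The entry for compound 3 is a limit and not a number, so the step has no upper bound: the limit of > 50000 nM in this assay, at which 1 of the 4 values shown sits.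

The compounds shown leave open whether the carboxylic acid itself matters in 4-carboxyphenyl, which a methyl ester, a primary amide or an amine on the same aromatic ring would help to test. They also leave open whether the steps among these aryl groups keep their size and direction when the silicon-bearing group of compound 1 stands on the oxygen on a saturated carbon, since every aryl exchange read so far has the smaller group of compound 3 at that place.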